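Ring expansion at the amide of a thiazole carboxamide

A few compounds are considered here, and "the series" means these few. Any claim that something is new, unique, unknown or untested is made for them only; others in the source may bear on it.

Measured compounds:
compound 1 `O=C(c1sc(-c2cccc(F)c2)nc1O)N1CCOC1` gives 5500 nM
compound 2 `CCn1nnc(-c2sc(-c3cccc(C)c3)nc2O)n1` gives 369 nM

Both numbers come from an assay on HEK293 cells for inhibition of transient receptor potential cation channel subfamily M member 8 (Homo sapiens), read by FLIPR, with stated times of 5 min and 3 min; a lower number here means a stronger inhibitor, a higher number a weaker inhibitor. Within the data shown here, compound 1 stands at the highest of the two values measured; its only neighbour, compound 2, sits well below it, and this gap is beyond the scatter. Among the measured compounds shown here, no pair of measured compounds differs in one place only, so no step has been measured directly.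

Compound 3 `O=C(c1sc(-c2cccc(F)c2)nc1O)N1CCOCC1` is not yet measured. It differs from compound 1 by a group of 6 heavy atoms (4 carbon, 1 nitrogen, 1 oxygen; one six-membered non-aromatic ring with 2 hetero atoms) in place of a group of 5 heavy atoms (3 carbon, 1 nitrogen, 1 oxygen; one five-membered non-aromatic ring with 2 hetero atoms), on a carbonyl carbon. For the measured compounds named here, no measured step of this kind exists here, so the expectation rests on the general size of such ring changes at an amide. Compound 3 is expected to lie near compound 1, with a step of a 1.4-fold lower number from compound 1 to compound 3 (0.14 log units; within the scatter) that stays within the scatter. The estimate for compound 3 in this assay is 4000 nM, expected to fall between 1500 nM and 12000 nM.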

Compound 3, half-maximal inhibitory concentration: 12200 nM
Compound 3: the middle estimate sits 3.1-fold (0.48 log units) below what was measured; the measured number lies above the stated range.
By their numbers in this assay, from the lowest: compound 2; then compound 1; then compound 3.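

In this assay, among these compounds, putting morpholin-4-yl in place of the five-membered ring on the carbonyl carbon gives a 2.2-fold higher number from compound 1 to compound 3 (0.35 log units; beyond the scatter), the first measured step at this position. The step is modest but beyond the scatter, so this position does respond to a change of ring, and here the six-membered ring gives the weaker inhibitor. No supporting measurement bears on this step, so the reason for it remains unknown.

Still open, going by these compounds, is how a piperidin-1-yl group, a piperazin-1-yl group or an open-chain dimethylamino group on the same carbonyl carbon would stand in this assay, and so whether this single step reflects ring size or the particular ring. On these data alone, compound 2 differs from compound 1 and compound 3 in more than one place, so which of its differences goes with its lower number also stays open.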